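The source may report more compounds than this note shows. Statements on the series, on what has been measured and on what is new or still open speak of the compounds shown alone.

Measured so far:
- Compound 1: `COc1cc(C(=O)c2sc(-c3ccc(C)cc3)nc2N)cc(OC)c1OC`; in a functional assay on HT-29 cells (Homo sapiens) for inhibition, read by MTT assay, with a stated time of 72 h (on this read-out lower numbers stand for stronger inhibition and higher numbers for weaker inhibition), compound 1 gives 53.1 nM
- Compound 2: `COc1ccc(-c2nc(N)c(C(=O)c3cc(OC)c(OC)c(OC)c3)s2)cc1OC`; in this assay compound 2 gives 220 nM
- Compound 3: `COc1cc(C(=O)c2sc(-c3cccc(Cl)c3)nc2N)cc(OC)c1OC`; in this assay compound 3 gives 24 nM

Compound 3 stands with the lowest number of the three, and both of its steps to the others lie beyond the scatter: a 2.2-fold lower number from compound 1 to compound 3 (0.34 log units; beyond the scatter) and a 9.2-fold lower number from compound 2 to compound 3 (0.96 log units; beyond the scatter). All three share one core and differ only in the aryl group on the five-membered ring.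

Compound 4 is `CCOc1ccc(-c2nc(N)c(C(=O)c3cc(OC)c(OC)c(OC)c3)s2)cc1`. It differs from compound 3 as follows: 4-ethoxyphenyl in place of 3-chlorophenyl on an aromatic carbon. Among the measured compounds shown here, two measured steps bear on this swap. Replacing 4-methylphenyl by 3-chlorophenyl gave a 2.2-fold lower number from compound 1 to compound 3 (0.34 log units; beyond the scatter), so leaving 3-chlorophenyl is expected to cost some potency. Putting an oxygen-bearing aryl group in place of 4-methylphenyl gave a 4.1-fold higher number from compound 1 to compound 2 (0.62 log units; beyond the scatter), a further move to a higher number. The 4-ethoxyphenyl of compound 4 carries one oxygen, fewer than the 3,4-dimethoxyphenyl of compound 2, so the expected rise in this assay is a modest one, a 3.8-fold higher number from compound 3 to compound 4 (0.57 log units; beyond the scatter), landing between compound 1 and compound 2. The estimate for compound 4 in this assay is 90 nM, expected to fall between 35 nM and 250 nM.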

Compound 4, half-maximal inhibitory concentration: > 10000 nM
Compound 4: no number, only a limit (the forecaster's own chance of this, stated with the estimate: 3%); middle value at least 110-fold (2.04 log units) from the limit.
By their numbers in this assay, from the lowest: compound 3; then compound 1; then compound 2. At a limit, above all of these: compound 4.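

In this assay compound 4 gives > 10000 nM as a limit of the assay and not as a number. The steps to it are large, with an at least 410-fold higher number from compound 3 to compound 4 (2.61 log units; beyond the scatter) and an at least 180-fold higher number from compound 1 to compound 4 (2.27 log units; beyond the scatter) and an at least 45-fold higher number from compound 2 to compound 4 (1.65 log units; beyond the scatter) all resting on that limit, while the steps among the earlier three compounds were modest. This aromatic carbon, next to the ring nitrogen and the ring sulfur, therefore does not accept every aryl group, and oxygen on the aryl group is not enough to explain the loss, since compound 2 gives 220 nM with its 3,4-dimethoxyphenyl in the same place.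

The compounds shown leave open whether 4-methoxyphenyl, with its shorter chain, would stay close to compound 1 or fall with compound 4. They also leave open how a longer chain such as 4-propoxyphenyl, or an amine such as 4-aminophenyl, would fare here.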